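From 2-chlorophenyl to 4-chlorophenyl on an amide-type nitrogen

The source may report more compounds than this note shows. Statements on the series, on what has been measured and on what is new or still open speak of the compounds shown alone.

In a functional assay on NCI-H460 cells (Homo sapiens) for inhibition, read by MTT assay, with a stated time of 24 h, tested at 1 ug/mL (on this read-out higher numbers stand for more inhibition of growth at the one concentration tested and lower numbers for less inhibition of growth), compound 3 (`CC(=O)SCCC(CCCCC(=O)Nc1ccccc1Cl)SC(C)=O`) gives 13.2% while compound 2 (`Cc1cccc(NC(=O)CCCCC(S)CCS)c1`) gives 9.43% and compound 1 (`O=C(CCCCC1CCSS1)Nc1ccc(Cl)cn1`) gives 6.26% and these three numbers lie within the usual scatter of one another. Among the measured compounds shown here, compound 4 (`CC(=O)SCCC(CCCCC(=O)Nc1ccc(Cl)cc1)SC(C)=O`) has no measurement yet. It carries 4-chlorophenyl in place of 2-chlorophenyl on an amide-type nitrogen. For the measured compounds named here, no measured pair isolates such a change, so the expectation rests on compound 3 at 13.2% and on the narrow spread of the three numbers. No step beyond the scatter is expected in either direction. The expected step of a number 2.2 percentage points lower from compound 3 to compound 4 (within the scatter) stays within the scatter. For compound 4 the estimated value is 11% (range 3% to 25%).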

Compound 4, percent growth inhibition at one concentration: 15.4%
For compound 4 the middle estimate is 4.4 percentage points below the measured one; low and high end bracket the measured number.
By their numbers in this assay, from the lowest: compounds 1, 2, 3 and 4 (each within the scatter of the next).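

Among the compounds shown here, this is the first pair that isolates a single change: with 4-chlorophenyl in place of 2-chlorophenyl on an amide-type nitrogen, this assay shows a number 2.2 percentage points higher from compound 3 to compound 4 (within the scatter). At this one concentration, the assay therefore does not separate these two chlorophenyl groups. No available evidence bears on why they read alike.

On these data alone, whether unsubstituted phenyl or 4-methoxyphenyl at this place would read differently remains open. So does whether the same change would behave alike in the compounds with the free thiols or the disulfide ring.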